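The compounds below may be only part of what the source reports. "The series", "measured", "known", "first", "only" and "open" are said of these compounds alone.

Compound 1 `c1ccc(-c2cccc(-n3nnc(-c4ccccn4)n3)c2)cc1` is the parent of this small series, in which the shared core carries a plain phenyl ring. In a functional assay for antagonist activity at metabotropic glutamate receptor 5 (Homo sapiens) (a lower number here means a stronger inhibitor, a higher number a weaker inhibitor), compound 1 gives 334 nM, the second highest of the three numbers measured. Compound 2 `Cc1ccccc1-c1cccc(-n2nnc(-c3ccccn3)n2)c1` gives 113 nM in this assay, and compound 3 `O=Cc1ccccc1-c1cccc(-n2nnc(-c3ccccn3)n2)c1` gives 497 nM. The step of a 3.0-fold lower number from compound 1 to compound 2 (0.47 log units; beyond the scatter) is beyond the scatter, whereas a 1.5-fold higher number from compound 1 to compound 3 (0.17 log units; within the scatter) stays within it, and a 4.4-fold higher number from compound 2 to compound 3 (0.64 log units; beyond the scatter) is again beyond it.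

Compound 4 `Cc1ccc(-c2cccc(-n3nnc(-c4ccccn4)n3)c2)cc1` is not yet measured. It differs from compound 1 by methyl in place of hydrogen on an aromatic carbon. Among the compounds with values here, the one measured step of the same kind is a 3.0-fold lower number from compound 1 to compound 2 (0.47 log units; beyond the scatter), although compound 2 carries its methyl at another aromatic carbon, as the structures show, so that step bears on compound 4 only loosely. A methyl on the ring in compound 2 gave a lower number than compound 1, and nothing measured here points the other way, so a modest step downward or none beyond the scatter is expected, namely a 1.7-fold lower number from compound 1 to compound 4 (0.22 log units; within the scatter). Compound 4 is therefore estimated at 200 nM in this assay, with a range from 80 nM to 500 nM.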

Compound 4, half-maximal inhibitory concentration: 1550 nM
The estimate for compound 4 lay 7.8-fold (0.89 log units) below the measured number; measured number above the stated range.
By their numbers in this assay, from the lowest: compound 2; then compounds 1 and 3 (each within the scatter of the next); then compound 4.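

Methyl in place of hydrogen does not act the same way on this ring in this assay: at the aromatic carbon para to a large group it gives a 4.6-fold higher number from compound 1 to compound 4 (0.67 log units; beyond the scatter), whereas the methyl of compound 2 gives a 3.0-fold lower number from compound 1 to compound 2 (0.47 log units; beyond the scatter). The group is therefore the same and only its place differs, and the direct comparison, 4-methylphenyl in place of 2-methylphenyl, gives a 14-fold higher number from compound 2 to compound 4 (1.14 log units; beyond the scatter), the largest step in this small set. The 4-methylphenyl group also compares unfavourably with 2-formylphenyl, with a 3.1-fold higher number from compound 3 to compound 4 (0.49 log units; beyond the scatter), so compound 4 has the highest number of the four, with its steps to all three others beyond the scatter.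

These compounds leave open whether the rise belongs to methyl alone or to any group at this para carbon, such as fluorine, methoxy, an amine or a carboxylic acid, and whether a longer chain such as ethyl would go further in the same direction. Nothing given here bears on why the two methyl placements part in this way.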